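Ring-opened side chain on the shared core

The compounds below may be only part of what the source reports. "The series", "measured", "known", "first", "only" and "open" are said of these compounds alone.

Compound 1 `O=C1CCC(N2C(=O)C(c3ccccc3)=C(c3ccccc3)C2=O)C(=O)N1` is measured in a functional assay on DLD-1 cells (Homo sapiens) for cytotoxicity, read by MTT assay; on this read-out lower numbers stand for stronger inhibition and higher numbers for weaker inhibition. In this assay compound 1 gives > 50000 nM, which is a limit of the assay and not a number. Compound 2 `CN(C)CCN1C(=O)CCC(N2C(=O)C(c3ccccc3)=C(c3ccccc3)C2=O)C1=O` carries 2-(dimethylamino)ethyl in place of hydrogen on an amide-type nitrogen in a ring. In this assay compound 2 gives > 50000 nM, again only a limit. The step that the two limits leave unreadable from compound 1 to compound 2 is therefore not readable in size. Both values sit at the limit of > 50000 nM in this assay, at which 2 of the 2 values shown sit. Compound 3 `NC(=O)CCC(C(=O)O)N1C(=O)C(c2ccccc2)=C(c2ccccc2)C1=O` differs from compound 1 by 3-carbamoyl-1-carboxypropyl in place of 2,6-dioxopiperidin-3-yl on an amide-type nitrogen in a ring. Among the compounds with values here, no measured step bears directly on this change; the only step known touches a different position and cannot be read. On that basis no shift beyond the scatter is expected, and compound 3 is expected to stay at the limit, with an estimate for compound 3 of 50000 nM, within 20000 nM to 200000 nM. The expected step of a number no higher from compound 1 to compound 3 (the limit leaves the size open) is thus expected to be essentially flat.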

Compound 3, half-maximal inhibitory concentration: > 50000 nM
Compound 3: no number, only a limit (the forecaster's own chance of this, stated with the estimate: 85%); the middle value sits exactly at the limit.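

Compound 1 and compound 3 give only limits in this assay, so no new step can be read between them: the limit of > 50000 nM in this assay, at which 3 of the 3 values shown sit.

The compounds shown leave open whether any change on the shared core gives a readable number in this assay, and how large such a step would be.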